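Methyl for Methoxy on the Sulfonyl Aryl Ring

The compounds below may be only part of what the source reports. "The series", "measured", "known", "first", "only" and "open" are said of these compounds alone.

compound 1 `COc1ccc(S(=O)(=O)NCCN2CCC(CCC(=O)c3cc(Cl)c(N)cc3OC)CC2)cc1Br`: 72%
compound 2 `COc1ccc(S(=O)(=O)NCCN2CCC(CCC(=O)c3cc(Cl)c(N)cc3OC)CC2)cc1`: 52%
compound 3 `COc1cc(N)c(Cl)cc1C(=O)CCC1CCN(CCNS(=O)(=O)c2ccc(C)cc2)CC1`: not yet measured

In an assay on HEK293 cells for displacement of a labelled ligand from 5-hydroxytryptamine receptor 6 (Homo sapiens), with a stated time of 60 min, tested at 1 uM, in the presence of a further agent that is not named here (on this read-out higher numbers stand for a stronger effect at the one concentration tested and lower numbers for a weaker effect), compound 1 gives 72%, and compound 2 gives 52%, the lower of the two numbers. Going by the values given here, the one measured step is a number 20 percentage points lower from compound 1 to compound 2 (beyond the scatter). Compound 3 differs from compound 2 by methyl in place of methoxy on an aromatic carbon, on an aromatic carbon para to a large group. Among the compounds with values here, that step concerns a different group at a different place, so no measured step bears on this change. The estimated step is a number 2 percentage points lower from compound 2 to compound 3 (within the scatter), expected to stay within the scatter. For compound 3 the expected value is 50%, with a range from 30% to 70%.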

Compound 3, a percentage reported as inhibition, at one concentration (the size of the read-out at that concentration, not a potency): 15%
The estimate for compound 3 lay 35 percentage points above the measured number, outside the stated range (below it).
By their numbers in this assay, from the lowest: compound 3; then compound 2; then compound 1.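

In this assay, 4-methylphenyl in place of 4-methoxyphenyl on the sulfonyl sulfur gives a number 37 percentage points lower from compound 2 to compound 3 (beyond the scatter), so the number depends on the methoxy group as well as on the bromo group. Changing both groups at once gives a number 57 percentage points lower from compound 1 to compound 3 (beyond the scatter), the largest step among these compounds. No evidence is available that accounts for this drop.

Going by these compounds, what remains open is whether a hydroxy, ethoxy or fluoro group in the same place would keep the number of compound 2, and whether adding bromo to the 4-methylphenyl ring would raise the number of compound 3.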